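The source may hold more compounds than are shown below. What is called first, only, known or untested is meant among the compounds shown, and "the series" means these compounds.

Compound 1 `CCOc1ccc(CN(Cc2ccc(C(C)(C)C)cc2)Cc2cc3cc(C)ccc3[nH]c2=O)cc1` was examined in a toxicity assay on MDCK cells (Canis lupus familiaris) for cytotoxicity, read by crystal violet staining, with a stated time of 48 h; a lower number here means that less compound is tolerated, a higher number that more compound is tolerated. In this assay compound 1 gives > 10000 nM, which is a limit of the assay and not a number. Compound 2 `Cc1ccc2[nH]c(=O)c(CN(Cc3ccc(C(C)(C)C)cc3)[C@H](C)c3ccc(F)cc3)cc2c1` carries 1-(4-fluorophenyl)ethyl in place of 4-ethoxybenzyl on an amine nitrogen. In this assay compound 2 gives > 5000 nM, again a limit of the assay. The step that the two limits leave unreadable from compound 1 to compound 2 is not readable; the two values sit at the limits the limit of > 10000 nM in this assay, at which 1 of the 2 values shown sits, and (the limit of > 5000 nM in this assay, at which 1 of the 2 values shown sits). Going by the values given here, compound 2 thus stands at a limit, and the one other value shown beside it is a limit as well.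

Compound 3 `COc1ccc(C(C)N(Cc2ccc(C(C)(C)C)cc2)Cc2cc3cc(C)ccc3[nH]c2=O)cc1` differs from compound 2 in one place: 1-(4-methoxyphenyl)ethyl in place of 1-(4-fluorophenyl)ethyl on an amine nitrogen. Among the compounds with values here, the only measured step that bears on this change is the one from compound 1 to compound 2, whose size is not readable, so no direction can be drawn from the data. The step that the limit leaves unreadable from compound 2 to compound 3 is accordingly expected to be none beyond the scatter. Compound 3 is therefore expected to give about 10000 nM in this assay, between 4000 nM and 30000 nM, and most likely the assay will again report only a limit.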

Compound 3, half-maximal cytotoxic concentration: > 5000 nM
Compound 3: no number, only a limit; the forecaster's own chance of this, stated with the estimate: 80%; the middle value does not contradict the limit.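

No new step can be read among compound 1, compound 2 and compound 3, since all three stand at limits of this assay: the limit of > 5000 nM in this assay, at which 2 of the 3 values shown sit.

The compounds shown leave open where any of the three would reach its half-maximal cytotoxic concentration, and so whether exchanging 4-ethoxybenzyl, 1-(4-fluorophenyl)ethyl and 1-(4-methoxyphenyl)ethyl on the amine nitrogen makes any difference.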